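From 3,4-difluorophenyl to 2-bromophenyl at the assay limit

This account rests on a few compounds, and the source may have more. Where it says the series, first, only, none or still open, it means among the compounds named here.

In a functional assay on MGC-803 cells (Homo sapiens) for antiproliferative activity, read by MTT assay, with a stated time of 72 h (a higher number here means a weaker inhibitor, a lower number a stronger inhibitor), compound 1 (`O=C(COc1ccc(C(=O)/C=C/c2ccc(F)c(F)c2)cc1)N[C@H]1CCOC1=O`) gives > 64000 nM as a limit, not a number. Compound 2 (`O=C(CNc1ccccc1F)N[C@H]1CCOC1=O`) likewise gives > 64000 nM as a limit. Compound 3 (`CCOc1ccccc1OCCSC(=S)N[C@H]1CCOC1=O`) also gives > 64000 nM as a limit. For the measured compounds named here, compound 1 therefore has no number of its own: the whole picture so far is the limit of > 64000 nM in this assay, at which 3 of the 3 values shown sit, and no measured pair offers a step to learn from.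

Going by the values given here, compound 4 (`O=C(COc1ccc(C(=O)/C=C/c2ccccc2Br)cc1)N[C@H]1CCOC1=O`) keeps the core of compound 1 and carries 2-bromophenyl in place of 3,4-difluorophenyl on a double-bonded chain carbon bound to a double-bonded chain carbon as its one change.

With compound 1 held at > 64000 nM as a limit, the step expected in this assay is none beyond the usual scatter, with only a slight lean toward a stronger inhibitor. The estimated move, an at least 1.0-fold lower number from compound 1 to compound 4 (0.02 log units; that floor lies within the scatter), is therefore small. For compound 4 the estimated half-maximal inhibitory concentration is 60000 nM with an expected range from 15000 nM to 100000 nM and a good chance of only a limit again.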

Compound 4, half-maximal inhibitory concentration: 12200 nM
Beside the measured number, compound 4's estimate is 4.9-fold (0.69 log units) above it; the whole stated range lies above it.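

For the compounds shown here, compound 4 is the first compound here with a real number in this assay, so the group on this double-bonded chain carbon can move the result away from the assay limit. Replacing 3,4-difluorophenyl with 2-bromophenyl gives an at least 5.2-fold lower number from compound 1 to compound 4 (0.71 log units; beyond the scatter). The full size of this step remains unknown because compound 1 has only a limit and not a number of its own: the limit of > 64000 nM in this assay, at which 3 of the 4 values shown sit.

This single swap both removes the fluorine atoms and adds a bromine, so the compounds shown cannot tell which of the two matters, or whether both do. Also open, as far as these compounds go, is how a plain phenyl or a chlorophenyl group would behave on the same carbon, which would help separate those two parts of the change.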